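The compounds below may be only part of what the source reports. "The series", "measured", "known", "first", "only" and "open" are said of these compounds alone.

Compound 1, `COc1ccc(-c2cc3nccc(-c4cc(OC)c(OC)c(OC)c4)n3n2)cc1N`, gives 283 nM.
Compound 2, `COc1cc(-c2ccnc3cc(-c4ccc(C(C)=O)cc4)nn23)cc(OC)c1OC`, gives 1810 nM.
Compound 3, `COc1cc(-c2ccnc3cc(-c4ccc(C)c(C)c4)nn23)cc(OC)c1OC`, gives 241 nM.

All three were measured in a functional assay on HeLa cells (Homo sapiens) for inhibition, read by CCK-8 assay, with a stated time of 48 h; a lower number here means a stronger inhibitor, a higher number a weaker inhibitor. Among these three numbers compound 1 stands second highest: its nearest neighbour is compound 3, within the usual scatter, while compound 2 gives the highest number of the set. The unmeasured compound 4, `COc1cc(-c2ccnc3cc(-c4cccc(C)c4)nn23)cc(OC)c1OC`, is reached from compound 1 by a single change: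

3-methylphenyl in place of 3-amino-4-methoxyphenyl on an aromatic carbon

Going by the values given here, two measured steps bear on this change. The step of a 1.2-fold lower number from compound 1 to compound 3 (0.07 log units; within the scatter) shows that exchanging the 3-amino-4-methoxyphenyl for a ring carrying only methyl groups left the number essentially where it was. The step of a 6.4-fold higher number from compound 1 to compound 2 (0.81 log units; beyond the scatter) shows a modest rise when a 4-acetylphenyl entered instead, and the step of a 7.5-fold lower number from compound 2 to compound 3 (0.88 log units; beyond the scatter) shows the same contrast from the other side. Since 3-methylphenyl is far closer in make-up to 3,4-dimethylphenyl than to 4-acetylphenyl, a step no larger than the within-scatter one just described is expected, with no clear direction. Compound 4 is therefore estimated at 300 nM, with a range from 120 nM to 750 nM, which corresponds to an expected step of a 1.1-fold higher number from compound 1 to compound 4 (0.03 log units; within the scatter).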

Compound 4, half-maximal inhibitory concentration: 4230 nM
Compound 4: middle estimate off by 14-fold (1.15 log units), on the low side; the whole stated range lies below it.
By their numbers in this assay, from the lowest: compounds 3 and 1 (each within the scatter of the next); then compound 2; then compound 4.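

In this assay, taking one methyl group off the 3,4-dimethylphenyl ring gives an 18-fold higher number from compound 3 to compound 4 (1.24 log units; beyond the scatter), so at this ring carbon a change as small as hydrogen in place of methyl outweighs the whole exchange of rings seen earlier between compound 1 and compound 3. The 3-methylphenyl ring also falls behind the 3-amino-4-methoxyphenyl ring, with a 15-fold higher number from compound 1 to compound 4 (1.17 log units; beyond the scatter), and behind the 4-acetylphenyl ring, with a 2.3-fold higher number from compound 2 to compound 4 (0.37 log units; beyond the scatter), so among these four compounds the three rings with a group at the 4 position, whether methoxy, acetyl or methyl, all give lower numbers than the one ring without it, and none of the four goes against this. Nothing given here explains why that single methyl group counts for so much.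

As far as these compounds go, it remains open whether a group at the 4 position is enough by itself or works only together with a group at the 3 position, a question that a 4-methylphenyl ring would address. From the compounds shown here alone, it is also open how a longer chain there, such as 4-ethylphenyl, or a 4-chlorophenyl ring would compare.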